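The source may report more compounds than this note shows. Statements on the series, on what has been measured and on what is new or still open speak of the compounds shown alone.

Of the compounds shown here, three have been measured in an ADME assay on MT4 cells (Homo sapiens) for cytotoxicity, read by MTT assay, with a stated time of 4 days; on this read-out higher numbers stand for lower toxicity in this test and lower numbers for higher toxicity in this test. Compound 1 `CCNc1nc(Nc2ccc(C#N)cc2)nc(Oc2ccc3cc(Br)ccc3c2Br)n1` gives 74400 nM in this assay. Compound 2 `CCCNc1nc(Nc2ccc(C#N)cc2)nc(Oc2ccc3cc(Br)ccc3c2Br)n1` differs from compound 1 by one change, (methyl in place of hydrogen on a saturated chain carbon, two bonds along the chain from a nitrogen on an aromatic ring), and in this assay compound 2 gives 134000 nM. That change made a 1.8-fold higher number from compound 1 to compound 2 (0.26 log units; within the scatter), so the two compounds cannot be told apart on this read-out.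

Compound 3 `CCNc1nc(Nc2ccc(C#N)cc2)nc(Oc2ccc3ccccc3c2Cl)n1` carries a different core; how the core of compound 3 differs from the core of compound 1 is not broken down here. In this assay compound 3 gives 188000 nM. Its value lies within the scatter of that of compound 2, and beyond the scatter from that of compound 1.

Compound 4 `CCCNc1nc(Nc2ccc(C#N)cc2)nc(Oc2ccc3ccccc3c2Cl)n1` has not yet been measured. It differs from compound 3 by methyl in place of hydrogen on a saturated chain carbon, two bonds along the chain from a nitrogen on an aromatic ring, the same change that leads from compound 1 to compound 2; among these compounds the change occurs twice in all, once measured and once not. Within the data shown here, the step from compound 3 to compound 4 in this assay is expected to be about a 1.3-fold higher number from compound 3 to compound 4 (0.12 log units; within the scatter), a small shift in the same direction, because the only earlier example of this change gave a 1.8-fold higher number from compound 1 to compound 2 (0.26 log units; within the scatter) on a core whose relation to that of compound 3 is not broken down here. Compound 4 is therefore estimated at 250000 nM, most likely falling between 120000 nM and 520000 nM.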

Compound 4, half-maximal cytotoxic concentration: > 290000 nM
Compound 4 gave a limit, no number; the forecaster's own chance of this, stated with the estimate: 25%; at least 1.1-fold (0.06 log units) between middle value and limit.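

In this assay compound 4 gives > 290000 nM, which is a limit of the assay and not a number. Replacing ethylamino with propylamino on the core of compound 3 gave an at least 1.5-fold higher number from compound 3 to compound 4 (0.18 log units; that floor lies within the scatter), while on the core of compound 1 the same change gave a 1.8-fold higher number from compound 1 to compound 2 (0.26 log units; within the scatter). The number did not fall on either core, but neither result establishes a real shift in toxicity in this test, and they do not show that the change has an effect of the same size on both cores: the same change on two cores in this assay, a 1.8-fold higher number (0.26 log units; within the scatter) from compound 1 to compound 2 and an at least 1.5-fold higher number (0.18 log units; that floor lies within the scatter) from compound 3 to compound 4; the limit leaves it open whether they differ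

The true value for compound 4 remains unknown, and the read-out gives no way to place it above the limit: the limit of > 290000 nM in this assay, at which 1 of the 4 values shown sits. The compounds shown also leave open what a longer chain than propylamino, or an ethylamino chain carrying a hydroxyl group or a carboxylic acid, would do on these two cores.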